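Swapping Amino for Chloro on a Shared Core

The compounds below may be only part of what the source reports. "The series", "measured", "known", "first", "only" and "open" are said of these compounds alone.

In a functional assay on HUVEC cells (Homo sapiens), read by fluorescence and microscopy, with a stated time of 6 h, tested at 10 uM (a lower number here means a stronger effect, a higher number a weaker effect of the compound at the concentration tested), compound 2 `N#Cc1c(Nc2ccc(N)cc2)sc2ccccc12` gives 1%, the lowest of the two numbers measured; compound 1 `N#Cc1c(Nc2ccc([N+](=O)[O-])cc2)sc2ccccc12` gives 8%, and the step of a number 7 percentage points lower from compound 1 to compound 2 (within the scatter) lies within the scatter. Compound 3 `N#Cc1c(Nc2ccc(Cl)cc2)sc2ccccc12` differs from compound 2 by chloro in place of amino on an aromatic carbon. Among the measured compounds shown here, the only measured step, from compound 1 to compound 2, put amino in place of nitro on an aromatic carbon and stayed within the scatter, and no measured step involves chloro, so nothing here points to a shift beyond the scatter. Compound 3 is therefore expected to give 5%, in a range from -10% to 25%, an expected step of a number 4 percentage points higher from compound 2 to compound 3 (within the scatter).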

Compound 3, a percentage reported as activity, at one concentration (the size of the read-out at that concentration, not a potency): 45%
Compound 3: middle estimate off by 40 percentage points, on the low side; measured number outside the range, above it.
By their numbers in this assay, from the lowest: compounds 2 and 1 (each within the scatter of the next); then compound 3.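

In this assay, the group on this aromatic carbon clearly matters: chloro gives a much weaker effect than amino, with a number 44 percentage points higher from compound 2 to compound 3 (beyond the scatter), and than nitro, with a number 37 percentage points higher from compound 1 to compound 3 (beyond the scatter). Compound 1 and compound 2 alone could not show this, since their values lie within the scatter of each other. Nothing available explains why chloro stands apart from the other two groups. Going by these compounds, whether bromo or fluoro would behave like chloro remains open. So does whether methoxy or hydroxyl would stay with amino and nitro.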